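Amide substituent exchanges and half-life in the series

The source may hold more compounds than are shown below. What is called first, only, known or untested is meant among the compounds shown, and "the series" means these compounds.

Three members of the series have been run in a physicochemical assay for pharmacokinetics, read by LC-MS, in phosphate buffer, at pH 7.4, in the presence of a further agent that is not named here; on this read-out lower numbers stand for a shorter-lived compound and higher numbers for a longer-lived compound. Compound 1 `C=CC(=O)N1CC(NC(=O)Cn2cc(C(=O)N3CCc4c(Cl)cccc4C3)c3cc(Br)ccc32)C1` gives 1.67 h. Compound 2 `C=CC(=O)N1CC(NC(=O)Cn2cc(C(=O)N(C)Cc3ccccc3)c3cc(Br)ccc32)C1` gives 1.67 h. Compound 3 `C=CC(=O)N1CC(NC(=O)Cn2cc(C(=O)NCc3ccccc3)c3cc(Br)ccc32)C1` gives 1.67 h, so compound 3 stands level with the other two at the digits recorded; compound 1 is its nearest neighbour and compound 2 its furthest, and neither gap exceeds the scatter. Every measured step is flat: no change at the digits printed from compound 1 to compound 2 (within the scatter), no change at the digits printed from compound 1 to compound 3 (within the scatter) and no change at the digits printed from compound 2 to compound 3 (within the scatter).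

Compound 4 `C=CC(=O)N1CC(NC(=O)Cn2cc(C(=O)N3CCc4cc(F)ccc4C3)c3cc(Br)ccc32)C1` has not yet been measured in this assay. It differs from compound 3 by 6-fluoro-1,2,3,4-tetrahydroisoquinolin-2-yl in place of benzylamino on a carbonyl carbon. The step from compound 1 to compound 3 is the one that bears most directly on this exchange, since it traded a group of the same ring pattern, carrying chlorine rather than fluorine, for benzylamino and showed no change at the digits printed from compound 1 to compound 3 (within the scatter); the other two steps, no change at the digits printed from compound 1 to compound 2 (within the scatter) and no change at the digits printed from compound 2 to compound 3 (within the scatter), likewise moved nothing beyond the scatter. On this basis the step expected from compound 3 to compound 4 is no change at the digits printed from compound 3 to compound 4 (within the scatter), with no direction beyond the scatter. For compound 4 the estimated value in this assay is 1.67 h, with a range from 0.9 h to 3.2 h.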

Compound 4, half-life: 1.67 h
For compound 4 middle estimate and measured number coincide at the digits printed, within the range that was stated.
By their numbers in this assay, from the lowest: compounds 1, 2, 3 and 4 (each within the scatter of the next).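

The 6-fluoro-1,2,3,4-tetrahydroisoquinolin-2-yl group adds a fluorine-bearing ring to the substituents on this carbonyl carbon, and in this assay its exchange for benzylamino gives no change at the digits printed from compound 3 to compound 4 (within the scatter), while its exchange for benzyl(methyl)amino gives no change at the digits printed from compound 2 to compound 4 (within the scatter). The new comparison is between halogens on the same ring pattern, with fluorine entering in place of chlorine, and it gives no change at the digits printed from compound 1 to compound 4 (within the scatter), so among these four compounds neither the identity of the halogen nor the choice between the fused ring and the open benzyl groups separates the half-lives. No supporting measurement bears on this flat result.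

From the compounds shown here alone, all the changes shown sit at this one carbonyl carbon and keep an aromatic carbon ring in the substituent, so it remains open whether a group of another kind there, such as a piperazine or a benzyl group carrying a carboxylic acid, would shift the half-life in this assay. Going by these compounds, the acrylamide and the bromine are common to all four compounds, so the effect of replacing them, for example with a saturated propanamide in place of the acrylamide, also remains open.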